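A hydroxyphenyl in place of a fluorophenyl on the carbonyl

The compounds below may be only part of what the source reports. "The series", "measured", "known", "first", "only" and "open" are said of these compounds alone.

Compound 2 `COc1cc(-c2nnc3n2NC(c2ccco2)C(C(=O)c2ccccc2F)S3)cc(OC)c1OC` shares its core with compound 1 `COc1ccc(C(=O)C2Sc3nnc(-c4cc(OC)c(OC)c(OC)c4)n3NC2c2ccco2)cc1` and compound 3 `COc1cc(-c2nnc3n2NC(c2cccs2)C(C(=O)c2ccc(Cl)cc2)S3)cc(OC)c1OC`. In a functional assay on MCF7 cells (Homo sapiens) for cytotoxicity, read by MTT assay, with a stated time of 48 h (a lower number here means a stronger inhibitor, a higher number a weaker inhibitor), compound 2 gives 94800 nM, the higher of the two numbers reported. Differing from compound 2 in two places, compound 3 gives 42800 nM in this assay, a step beyond the scatter. Compound 1 in this assay reaches only a limit, > 100000 nM, so that no number is known for it (the limit of > 100000 nM in this assay, at which 1 of the 3 values shown sits). Going by the values given here, the single measured change on the carbonyl carbon, an at least 1.0-fold lower number from compound 1 to compound 2 (0.02 log units; that floor lies within the scatter), lies within the scatter.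

Compound 4 `COc1cc(-c2nnc3n2NC(c2ccco2)C(C(=O)c2ccc(O)cc2)S3)cc(OC)c1OC` differs from compound 2 by 4-hydroxyphenyl in place of 2-fluorophenyl on a carbonyl carbon. Among the compounds with values here, this is the same position that the one measured step touched, and that step moved the number only within the scatter. Compound 2 to compound 3 also changes this group, but together with the five-membered ring, so it shows nothing on its own. The expected step of a 1.2-fold lower number from compound 2 to compound 4 (0.07 log units; within the scatter) is therefore none beyond the scatter, since an at least 1.0-fold lower number from compound 1 to compound 2 (0.02 log units; that floor lies within the scatter) was itself within it. Compound 4 is expected to give about 80000 nM in this assay, with a range from 30000 nM to 200000 nM, and with a real chance that only a limit is reported.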

Compound 4, half-maximal inhibitory concentration: 88900 nM
Compound 4: the middle estimate sits 1.1-fold (0.05 log units) below what was measured; low and high end bracket the measured number.
By their numbers in this assay, from the lowest: compound 3; then compounds 4 and 2 (each within the scatter of the next). At a limit, above all of these: compound 1.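

At this position on the carbonyl carbon, the step from 2-fluorophenyl to 4-hydroxyphenyl in this assay is a 1.1-fold lower number from compound 2 to compound 4 (0.03 log units; within the scatter), so the entering group's 1 hydrogen-bond donor and 1 hydrogen-bond acceptor come with no change that can be told from the scatter. Unlike the earlier step at this position, which had only a floor to offer, this one joins two actual numbers and so gives the first real reading of a change on this carbonyl carbon. Hydrogen in place of methyl on an oxygen on an aromatic ring gives an at least 1.1-fold lower number from compound 1 to compound 4 (0.05 log units; that floor lies within the scatter), but that step too is only a floor, since its starting point is a limit: the limit of > 100000 nM in this assay, at which 1 of the 4 values shown sits.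

As far as these compounds go, it remains open whether any group on this carbonyl carbon can move the number beyond the scatter, as an amine or a carboxylic acid on the phenyl ring might show. Compound 3 gives 42800 nM in this assay, but it differs from compound 2 in two places, so the share of each change stays unresolved.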